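Replacing an ethyl ketone with a nitrophenyl ketone

This account rests on a few compounds, and the source may have more. Where it says the series, first, only, none or still open, it means among the compounds named here.

Measured compounds:
compound 1 `CC(=O)c1ccc2c(c1)C(n1ccccc1=O)=CC(C)(C)O2` — 7.37
compound 2 `CCC(=O)c1ccc2c(c1)C(n1ccccc1=O)=CC(C)(C)O2` — 6.63

Compound 2 gives the lower of the two numbers in a functional assay (aorta) with Rattus norvegicus as the target; on this read-out lower numbers stand for lower potency and higher numbers for higher potency (the scale is a negative logarithm); its nearest neighbour, compound 1, stands higher by a step that lies beyond the scatter. Among the compounds with values here, the only step measured so far, a number 0.74 log units lower from compound 1 to compound 2 (beyond the scatter), came with a methyl in place of hydrogen on a saturated chain carbon bound to the carbonyl carbon: a larger chain on the carbonyl went with a modest loss.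

Compound 3 `CC1(C)C=C(n2ccccc2=O)c2cc(C(=O)c3ccccc3[N+](=O)[O-])ccc2O1` takes a further step from compound 2: 2-nitrophenyl in place of ethyl on a carbonyl carbon. Within the data shown here, no measured step covers an aromatic ring on this carbonyl carbon, so the step from ethyl to methyl bears on it only loosely. The change is expected to be modest in either direction, with wide uncertainty; the expected step is a number 0.17 log units higher from compound 2 to compound 3 (within the scatter). Compound 3 is therefore estimated at 6.8, within 5.9 to 7.7.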

Compound 3, logarithm of the reciprocal of the active concentration, log(1/C): 6.17
Compound 3: the middle estimate sits 0.63 log units above what was measured; low and high end bracket the measured number.
By their numbers in this assay, from the lowest: compound 3; then compound 2; then compound 1.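

In this assay, putting an aromatic ring on the carbonyl carbon did not recover potency: 2-nitrophenyl in place of ethyl lowered the number further (a number 0.46 log units lower from compound 2 to compound 3 (beyond the scatter)). Measured against the smallest group of the three, the methyl ketone, the change is larger still (a number 1.20 log units lower from compound 1 to compound 3 (beyond the scatter)), so this position clearly responds to what sits on the carbonyl carbon, and among these three compounds the number falls as that group gets larger. Nothing available here explains why the number falls.

As far as these compounds go, whether the loss belongs to the ring itself or to its nitro group stays open, and a plain phenyl ring on the carbonyl carbon would help to separate the two. Also open, from the compounds shown here alone, is how an amine on this carbonyl carbon, giving an amide, would compare with the methyl ketone of compound 1 (7.37).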